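Compound 3 after two unreadable limits

This account rests on a few compounds, and the source may have more. Where it says the series, first, only, none or still open, it means among the compounds named here.

Compound 1 `OC[C@H]1O[C@@H](n2cnc3c(NCc4ccccc4Cl)ncnc32)[C@H](O)[C@@H]1O` gives > 166000 nM as a limit.
Compound 2 `OC[C@H]1O[C@@H](n2cnc3c(NCc4ccc(F)c(F)c4F)ncnc32)[C@H](O)[C@@H]1O` gives > 166000 nM as a limit.

Both entries come from a functional assay on HOS cells (Homo sapiens) for antiproliferative activity, with a stated time of 72 h (a higher number here means a weaker inhibitor, a lower number a stronger inhibitor), and neither is a number. Compound 2 is known only through its limit of > 166000 nM and so has no exact place on the scale. Within the data shown here, the whole series so far amounts to the limit of > 166000 nM in this assay, at which 2 of the 2 values shown sit, and offers no measured potency to build on.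

Compound 3 `Cc1cccc(CNc2ncnc3c2ncn3[C@@H]2O[C@H](CO)[C@@H](O)[C@H]2O)c1O` brings the next change, (2-hydroxy-3-methylphenyl in place of 2,3,4-trifluorophenyl on a saturated chain carbon bound to a nitrogen on an aromatic ring). In words, this is 2-hydroxy-3-methylphenyl in place of 2,3,4-trifluorophenyl on a saturated chain carbon bound to a nitrogen on an aromatic ring.

Among the measured compounds shown here, the only measured step, a step that the two limits leave unreadable from compound 1 to compound 2, has no size that can be carried over. It also did not involve the entering 2-hydroxy-3-methylphenyl. A move toward stronger inhibition in this assay therefore remains possible but has no measured support, and the expectation stays close to the limit, with only a slight lean toward a measurable value. The estimated change is an at least 1.6-fold lower number from compound 2 to compound 3 (0.22 log units; that floor lies within the scatter) as an expected step. For compound 3 the expected value is 100000 nM, with an estimated range of 8000 nM to 166000 nM.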

Compound 3, half-maximal inhibitory concentration: > 166000 nM
Compound 3: no number, only a limit; the forecaster's own chance of this, stated with the estimate: 60%; at least 1.6-fold (0.22 log units) between middle value and limit.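

In this assay compound 3 gives > 166000 nM, again a limit and not a number. The steps linking compound 1, compound 2 and compound 3 therefore cannot be read. The compounds shown leave open whether any group on the saturated chain carbon bound to a nitrogen on an aromatic ring gives a measurable potency, as the series still stands at a single mark: the limit of > 166000 nM in this assay, at which 3 of the 3 values shown sit.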